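Adding bromo to the dichlorophenyl compound's core

The source may hold more compounds than are shown below. What is called first, only, known or untested is meant among the compounds shown, and "the series" means these compounds.

In a functional assay on UACC-62 cells (Homo sapiens) (on this read-out higher numbers stand for weaker inhibition of growth and lower numbers for stronger inhibition of growth), compound 1 (`O=S(=O)(/C=C/c1ccccc1)Cc1ccc(Nc2ncnc3ccccc23)cc1`) gives > 100000 nM and this is a limit of the assay, not a number. For the measured compounds named here, compound 2 (`O=S(=O)(/C=C/c1ccc(Cl)c(Cl)c1)Cc1ccc(Nc2ncnc3ccccc23)cc1`) gives 21000 nM as the only actual number so far. Going by the values given here, the change of phenyl to 3,4-dichlorophenyl gives an at least 4.7-fold lower number from compound 1 to compound 2 (0.67 log units; beyond the scatter) as the single measured step, and it is beyond the scatter.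

Compound 3 (`O=S(=O)(/C=C/c1ccc(Cl)c(Cl)c1)Cc1ccc(Nc2ncnc3ccc(Br)cc23)cc1`) differs from compound 2 by bromo in place of hydrogen on an aromatic carbon of the shared core, in a six-membered aromatic ring of carbon only that is part of a fused system: bromo in place of hydrogen on an aromatic carbon is the whole change. Among the compounds with values here, no measured step touches this place. The nearest guide is compound 2 with its an at least 4.7-fold lower number from compound 1 to compound 2 (0.67 log units; beyond the scatter) at the other end of the molecule, and it supports only a weak expectation of a modest move toward stronger inhibition of growth in this assay. The expected move is a 1.9-fold lower number from compound 2 to compound 3 (0.28 log units; within the scatter) on this estimate. For compound 3 the estimated value is 11000 nM with an expected range of 3000 nM to 40000 nM in this read-out.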

Compound 3, concentration for 50% growth inhibition: 30000 nM
Compound 3: the middle estimate sits 2.7-fold (0.44 log units) below what was measured; low and high end bracket the measured number.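

In this assay, for the compounds shown here, the only step on this part of the shared core is bromo in place of hydrogen on an aromatic carbon of the six-membered aromatic ring of carbon only, and it gives a 1.4-fold higher number from compound 2 to compound 3 (0.15 log units; within the scatter). Compounds 2 and 3 therefore cannot be told apart on this read-out, so this position accepts a bromo group with no effect that can be distinguished from assay noise, at least on the 3,4-dichlorophenyl background. Among the steps shown, only the exchange at the other end of the molecule, an at least 4.7-fold lower number from compound 1 to compound 2 (0.67 log units; beyond the scatter), lies beyond the scatter, so the core position and the 3,4-dichlorophenyl end do not behave alike here.

Compound 1 stands at a limit of the assay and not at a number, which leaves the phenyl background without a measured baseline in this assay: the limit of > 100000 nM in this assay, at which 1 of the 3 values shown sits. On these data alone, what remains open is whether a group other than bromo at this place, such as an amine, methoxy or a carboxylic acid, would move the read-out beyond the scatter, and whether bromo would behave the same way on the core of compound 1.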